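The source may report more compounds than this note shows. Statements on the series, on what has been measured and on what is new or still open speak of the compounds shown alone.

The compounds in this set share one core and differ in the group on the ring nitrogen and, for the new entry, on the chain. Compound 1 `COc1cccc(N2CCN(C(=O)C(C)N3C(=O)CCC3=O)CC2)c1` gives 25% in a functional assay on the whole organism (strain Swiss) with Mus musculus as the target, in the maximal electroshock model, with a stated time of 0.25 h, at a dose of 100 mg/kg by the intraperitoneal route; a higher number here means a stronger effect of the compound at the dose given, a lower number a weaker effect. Compound 2 `CC(C(=O)N1CCN(c2ccccc2)CC1)N1C(=O)CCC1=O` gives 50% in this assay, and compound 3 `CC(C(=O)N1CCN(c2ccc(F)cc2)CC1)N1C(=O)CCC1=O` gives 75%. Compound 2 stands second highest of the three measured numbers: on one side lies a number 25 percentage points higher from compound 1 to compound 2 (beyond the scatter), on the other a number 25 percentage points higher from compound 2 to compound 3 (beyond the scatter), both beyond the scatter.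

Compound 4 `CCC(C(=O)N1CCN(c2ccccc2)CC1)N1C(=O)CCC1=O` differs from compound 2 by methyl in place of hydrogen on a saturated chain carbon, two bonds along the chain from an amide-type nitrogen in a ring and a carbonyl carbon. Among the compounds with values here, none of the measured steps touches this position. The three steps recorded so far — a number 25 percentage points higher from compound 1 to compound 2 (beyond the scatter), a number 50 percentage points higher from compound 1 to compound 3 (beyond the scatter) and a number 25 percentage points higher from compound 2 to compound 3 (beyond the scatter) — all concern the aromatic ring on the amine nitrogen, and the chain carbon stays the same in every measured compound. There is therefore no direct guide for the change from compound 2 to compound 4, and a small group of one carbon at a place the measured steps never varied gives no grounds to expect a step beyond the scatter in this assay, in either direction. The expected step is no change at the digits printed from compound 2 to compound 4 (within the scatter). Compound 4 is estimated at 50%, with a range from 25% to 75%.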

Compound 4, a percentage reported as activity, at one dose (the size of the read-out at that dose, not a potency): 25%
Compound 4: the middle estimate sits 25 percentage points above what was measured, within the range that was stated.
By their numbers in this assay, from the lowest: compounds 1 and 4 (each within the scatter of the next); then compound 2; then compound 3.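

Until compound 4, every step lay on the aromatic ring on the amine nitrogen, and the saturated chain carbon had stayed the same throughout. With methyl in place of hydrogen at that carbon, this assay gives a number 25 percentage points lower from compound 2 to compound 4 (beyond the scatter) and so shows that this position is not silent: the addition of one carbon changes the read-out by more than the usual scatter, and the step has the same printed size as a number 25 percentage points higher from compound 2 to compound 3 (beyond the scatter) but runs the other way. Nothing available accounts for this fall in the read-out.

The compounds shown leave open whether a longer chain such as propyl, or a hydroxyl or an amine on the same carbon, would lower the number further, level off or reverse the step. They also do not tell whether methyl in place of hydrogen at this carbon would have the same effect with 4-fluorophenyl or 3-methoxyphenyl on the amine nitrogen, since the step has been read only with the unsubstituted phenyl of compound 2.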